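The compounds below may be only part of what the source reports. "The series", "measured", "known", "first", "only" and "open" are said of these compounds alone.

Measured so far in a functional assay on MCF7 cells (Homo sapiens) for antiproliferative activity, read by sulforhodamine B assay, with a stated time of 48 h; on this read-out higher numbers stand for weaker inhibition and lower numbers for stronger inhibition:

compound 1 `CCC(=O)Nc1ccc(S(=O)(=O)Oc2ccccc2C(C)C)cc1`: 11000 nM
compound 2 `CCC(=O)Nc1ccc(S(=O)(=O)Oc2ccccc2I)cc1`: 8100 nM
compound 3 `CC(C)c1ccccc1OS(=O)(=O)c1ccc(NC(=O)CCCl)cc1`: 9000 nM

Going by the values given here, the three measured compounds sit close together; no step among them is beyond the usual scatter, so no ordering of potency can be drawn from them. Compound 2 differs from compound 1 by iodo in place of isopropyl on an aromatic carbon, and that change gave a 1.4-fold lower number from compound 1 to compound 2 (0.13 log units; within the scatter). Compound 3 differs from compound 1 by chloro in place of hydrogen on a saturated chain carbon, two bonds along the chain from a carbonyl carbon, with a 1.2-fold lower number from compound 1 to compound 3 (0.09 log units; within the scatter).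

Compound 4 `O=C(CCCl)Nc1ccc(S(=O)(=O)Oc2ccccc2I)cc1` has not yet been measured in this assay. It differs from compound 3 by iodo in place of isopropyl on an aromatic carbon. This is the same change already made from compound 1 to compound 2, and the place of the change reads the same in both pairs; the cores of the two pairs differ by chloro in place of hydrogen on a saturated chain carbon, two bonds along the chain from a carbonyl carbon. The change occurs twice among the compounds shown and has one measured step behind it.

For compound 4 the expected step is a 1.4-fold lower number from compound 3 to compound 4 (0.14 log units; within the scatter), because a 1.4-fold lower number from compound 1 to compound 2 (0.13 log units; within the scatter) is the one earlier instance of this change and stayed within the scatter, and nothing among the shown compounds suggests the core of compound 3 should behave differently. The estimate for compound 4 in this assay is therefore 6500 nM, with the likely range running from 3000 nM to 14000 nM. This rests on a single precedent and on three closely grouped values, so the range is kept wide.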

Compound 4, half-maximal inhibitory concentration: 8900 nM
The estimate for compound 4 lay 1.4-fold (0.14 log units) below the measured number; low and high end bracket the measured number.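

In this assay, iodo in place of isopropyl on an aromatic carbon gives a 1.0-fold lower number from compound 3 to compound 4 (0.00 log units; within the scatter), and this change reads alike on the core of compound 1 and the core of compound 3: the same change on two cores in this assay, a 1.4-fold lower number (0.13 log units; within the scatter) from compound 1 to compound 2 and a 1.0-fold lower number (0.00 log units; within the scatter) from compound 3 to compound 4, 1.3-fold (0.13 log units) apart, within the scatter of two such steps. Chloro in place of hydrogen on a saturated chain carbon, two bonds along the chain from a carbonyl carbon, gives a 1.1-fold higher number from compound 2 to compound 4 (0.04 log units; within the scatter), and it too reads alike whether isopropyl or iodo is present: the same change on two cores in this assay, a 1.2-fold lower number (0.09 log units; within the scatter) from compound 1 to compound 3 and a 1.1-fold higher number (0.04 log units; within the scatter) from compound 2 to compound 4, 1.3-fold (0.13 log units) apart, within the scatter of two such steps. This shows that each change carried from one core to the other here without a step beyond the scatter, but with every step this small, it cannot separate a modest real dependence on the core from none, and two cores say nothing about any further core.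

The compounds shown leave open whether any change in this series can move the number beyond the scatter, so that a carried step could be tested on a step of real size. That could be read from an amine or a carboxylic acid in place of isopropyl or iodo on the aromatic carbon, or from a longer chain on the carbonyl carbon.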